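A chain in place of a ring in compound 3

A few compounds are considered here, and "the series" means these few. Any claim that something is new, unique, unknown or untested is made for them only; others in the source may bear on it.

Compound 1 `NCCCCNc1nc(Nc2ccc(Oc3nccs3)cc2)c2ncn(C3CCCC3)c2n1` gives 18600 nM
Compound 2 `N[C@H]1CC[C@H](Nc2nc(Nc3ccc(Oc4ccc(Br)cn4)cc3)c3ncn(C4CCCC4)c3n2)CC1` gives > 40000 nM as a limit
Compound 3 `N[C@H]1CC[C@H](Nc2nc(Nc3ccc(N4CCN(Cc5ccccc5)CC4)cc3)c3ncn(CCCO)c3n2)CC1` gives 16500 nM

All three values come from an ADME assay on BJ cells (Homo sapiens) for inhibition, read by fluorescence and resazurin assay, with a stated time of 72 h (a lower number here means a stronger inhibitor of growth, a higher number a weaker inhibitor of growth), and nothing separates the two numbers. Compound 3 stands at 16500 nM within the scatter of compound 1 at 18600 nM and the two cannot be ranked. Compound 2 gives > 40000 nM and that is a limit, not a number.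

Compound 4 `NCCCCNc1nc(Nc2ccc(N3CCN(Cc4ccccc4)CC3)cc2)c2ncn(CCCO)c2n1` has not yet been measured. Among the measured compounds shown here, it carries 4-aminobutyl in place of 4-aminocyclohexyl on a nitrogen on an aromatic ring and no measured pair isolates this change. Compound 1 also carries 4-aminobutyl and gives 18600 nM so no step beyond the scatter is expected in this assay here. The expected change is a 1.1-fold lower number from compound 3 to compound 4 (0.04 log units; within the scatter) and no direction is favoured. Compound 4 is estimated at 15000 nM with 6000 nM to 36000 nM as the expected range.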

Compound 4, concentration for 50% growth inhibition: 28500 nM
Estimate against measurement, compound 4: 1.9-fold (0.28 log units) below; low and high end bracket the measured number.
By their numbers in this assay, from the lowest: compounds 3, 1 and 4 (each within the scatter of the next). At a limit, above all of these: compound 2.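

In this assay, among the compounds shown here, 4-aminobutyl in place of 4-aminocyclohexyl on a nitrogen on an aromatic ring gives a 1.7-fold higher number from compound 3 to compound 4 (0.24 log units; within the scatter) and is the first measured pair to isolate this change. At this position, with the rest of the structure held, the open chain and the ring therefore cannot be told apart. Nothing measured here bears on the reason for this result.

Going by these compounds, it remains open whether a longer chain at this place, or a carboxylic acid in place of the amine, would separate from these two groups.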